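The source may report more compounds than this note shows. Statements on the series, on what has been measured and on what is new or still open speak of the compounds shown alone.

Compound 1 `O=C(N1CCOCC1)n1cc(-c2ccc3cn[nH]c3c2)ccc1=O` carries a (morpholin-4-yl)carbonyl on the aromatic nitrogen of the shared core. In an assay for inhibition of MAP kinase-interacting serine/threonine-protein kinase 2 (Homo sapiens), read by luminescence and ADP-Glo, with a stated time of 2 h (a lower number here means a stronger inhibitor, a higher number a weaker inhibitor), compound 1 reaches only the limit of the assay, > 2000 nM, and no number. Compound 2 `O=c1ccc(-c2ccc3cn[nH]c3c2)cn1Cc1ccccc1Cl` carries a 2-chlorobenzyl there instead, and in this assay compound 2 gives 78 nM. Within the data shown here, compound 2 thus holds the only number in this set; the other value is a limit (the limit of > 2000 nM in this assay, at which 1 of the 2 values shown sits). Compound 3 `O=c1ccc(-c2ccc3cn[nH]c3c2)cn1Cc1ccccc1F` differs from compound 2 by fluoro in place of chloro on an aromatic carbon. Among the measured compounds shown here, the one measured step, an at least 25-fold lower number from compound 1 to compound 2 (1.40 log units; beyond the scatter), exchanges the whole group on the aromatic nitrogen and says nothing about swapping one halogen for another on the benzyl ring, so no measured step bears directly on this change. The step of a 1.4-fold higher number from compound 2 to compound 3 (0.15 log units; within the scatter) is therefore expected to stay within the scatter. In this assay compound 3 is estimated at 110 nM, between 40 nM and 300 nM.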

Compound 3, half-maximal inhibitory concentration: 37 nM
For compound 3 the middle estimate is 3.0-fold (0.47 log units) above the measured one; the measured number lies below the stated range.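

In this assay, the halogen on the benzyl ring is not interchangeable: with fluoro in place of chloro on an aromatic carbon, ortho to a large group, the result is a 2.1-fold lower number from compound 2 to compound 3 (0.32 log units; beyond the scatter). Among these compounds, this is the first reading of this position on its own, and it shows that the exchange of one halogen for another moves the result modestly but beyond the scatter, though only this single pair speaks to it. The larger exchange, 2-fluorobenzyl in place of (morpholin-4-yl)carbonyl on the aromatic nitrogen, gives an at least 54-fold lower number from compound 1 to compound 3 (1.73 log units; beyond the scatter), and that step rests on a limit for compound 1, not on a number: the limit of > 2000 nM in this assay, at which 1 of the 3 values shown sits.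

From the compounds shown here alone, what a methyl, a methoxy or a bare hydrogen would do on this carbon remains open. So does whether fluoro and chloro keep the same order on another carbon of the benzyl ring.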